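Chloro to methylsulfanyl: a step read through limits

The source may report more compounds than this note shows. Statements on the series, on what has been measured and on what is new or still open speak of the compounds shown alone.

In an ADME assay on L929 cells (Mus musculus) for cytotoxicity, read by resazurin assay, with a stated time of 72 h (on this read-out higher numbers stand for weaker inhibition and lower numbers for stronger inhibition), compound 3 `O=C(/C=C/c1ccc2c(c1)B(O)OC2)c1ccc(Cl)cc1` gives > 10 ug/mL as a limit and not as a number. Compound 1 `O=C(/C=C/c1ccc2c(c1)B(O)OC2)c1ccc(O)cc1` gives > 10 ug/mL and this too is a limit. Compound 2 `O=C(/C=C/c1ccc2c(c1)B(O)OC2)c1ccc(Br)cc1` gives > 10 ug/mL and this is also a limit. The picture so far is the limit of > 10 ug/mL in this assay, at which 3 of the 3 values shown sit, and no true number is known for any of the three.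

Compound 4 `CSc1ccc(C(=O)/C=C/c2ccc3c(c2)B(O)OC3)cc1` differs from compound 3 by a single group. The change is methylsulfanyl in place of chloro on an aromatic carbon and in words it puts methylsulfanyl in place of chloro on an aromatic carbon.

Three measured swaps of one group bear on this change: a step that the two limits leave unreadable from compound 1 to compound 2 with bromo in place of hydroxy, a step that the two limits leave unreadable from compound 1 to compound 3 with chloro in place of hydroxy, and a step that the two limits leave unreadable from compound 2 to compound 3 with chloro in place of bromo. None of them has a size that can be read, so they offer no direction for the new swap. All three compounds stayed at the limit, so the expectation in this assay is no step beyond the scatter, and a result reported only as a limit is the likeliest outcome. The expected move is a step that the limit leaves unreadable from compound 3 to compound 4 and it remains only an estimate. For compound 4 the estimated value is 15 ug/mL with an expected range from 7 ug/mL to 40 ug/mL in this assay as the measure.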

Compound 4, half-maximal inhibitory concentration: > 10 ug/mL
Compound 4 ended at the assay's limit; the forecaster's own chance of this, stated with the estimate: 80%; the middle value lies beyond the limit too.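

Going by these compounds alone, compound 4 gives only a limit, as do compound 1, compound 2 and compound 3, so no step from any of these three to compound 4 can be read in this assay. All four share one result: the limit of > 10 ug/mL in this assay, at which 4 of the 4 values shown sit. The compounds shown leave open where the true values lie and whether the four differ at all.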